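This account rests on a few compounds, and the source may have more. Where it says the series, first, only, none or still open, it means among the compounds named here.

The series shares the core of compound 1, `CC(C)c1cccc(C(C)C)c1NC(=O)CC(=O)O`, an acid whose value in an assay on microsomes from intestine for inhibition of acyl-CoA:cholesterol acyltransferase (Oryctolagus cuniculus) (a lower number here means a stronger inhibitor, a higher number a weaker inhibitor), is reported only as a limit, > 5000 nM, noted as the limit of > 5000 nM in this assay, at which 1 of the 3 values shown sits. Compound 2, `CCOC(=O)CC(=O)Nc1c(C(C)C)cccc1C(C)C`, gives 1800 nM in this assay, and compound 3, `CCCCCCCCCCOC(=O)CC(=O)Nc1c(C(C)C)cccc1C(C)C`, gives 53 nM. Among the two numbers shown, compound 2 therefore stands highest; its nearest neighbour is compound 3, reached by a 34-fold lower number from compound 2 to compound 3 (1.53 log units; beyond the scatter). The other measured step, from the acid to its ethyl ester, is an at least 2.7-fold lower number from compound 1 to compound 2 (0.44 log units; beyond the scatter), a change described as ethyl in place of hydrogen on an oxygen next to a carbonyl group.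

Compound 4, `CC(C)c1cccc(C(C)C)c1NC(=O)CC(=O)OC(C)(C)C`, differs from compound 2 in one place: tert-butyl in place of ethyl on an oxygen next to a carbonyl group. Both measured steps bear on it, since each lengthens the ester side, and both lowered the number, the octyl extension doing so strongly. A tert-butyl extension is smaller than octyl, so a modest lowering in this assay is expected, about a 3.0-fold lower number from compound 2 to compound 4 (0.48 log units; beyond the scatter). Compound 4 is thus estimated at 600 nM, within a range from 200 nM to 2000 nM.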

Compound 4, half-maximal inhibitory concentration: 130 nM
For compound 4 the middle estimate is 4.6-fold (0.66 log units) above the measured one; measured number outside the range, below it.
By their numbers in this assay, from the lowest: compound 3; then compound 4; then compound 2. At a limit, above all of these: compound 1.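

In this assay, for the compounds shown here, the swap on the ester oxygen gives a 14-fold lower number from compound 2 to compound 4 (1.14 log units; beyond the scatter), so a large step at this position does not require a long chain: a compact, branched tert-butyl group also delivers one, whereas the only large step seen before came with the octyl extension, a 34-fold lower number from compound 2 to compound 3 (1.53 log units; beyond the scatter). Set against the acid, the same ester gives an at least 38-fold lower number from compound 1 to compound 4 (1.58 log units; beyond the scatter). That step is only a bound, as the value of compound 1 is a limit and not a number: the limit of > 5000 nM in this assay, at which 1 of the 4 values shown sits.

The compounds shown leave open whether an isopropyl ester or a straight butyl ester would fall nearer compound 2 or compound 4, and so whether branching or chain length matters more here. Going by these compounds, whether a tert-butyl amide would keep this step also remains open.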